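Adding a 1-hydroxybutyl group to compound 2

The compounds below may be only part of what the source reports. "The series", "measured", "known", "first", "only" and "open" are said of these compounds alone.

Measured so far in a functional assay on cells (Neutrophil, Homo sapiens) for inhibition, with a stated time of 10 min; a higher number here means a weaker inhibitor, a lower number a stronger inhibitor:
compound 1 `CCCC(O)Cn1ncc(C(=O)OCC)c1NC(=O)NC(C)C`: 1 nM
compound 2 `CCOC(=O)c1cnn(C)c1NC(=O)NCc1ccccc1`: 1.3 nM

Among the measured compounds shown here, compound 2, at 1.3 nM, lies within the scatter of compound 1, the only other compound measured. Compound 3 `CCCC(O)Cn1ncc(C(=O)OCC)c1NC(=O)NCc1ccccc1` differs from compound 2 by one change, 1-hydroxybutyl in place of hydrogen on a saturated chain carbon bound to an aromatic nitrogen. The resulting 2-hydroxypentyl also stands in compound 1 at 1 nM. For the measured compounds named here, no measured step shows this change, so no step beyond the scatter is expected in this assay. The expected 1.2-fold higher number from compound 2 to compound 3 (0.06 log units; within the scatter) is small. For compound 3 the estimate is 1.5 nM, with an expected range of 0.4 nM to 5 nM.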

Compound 3, half-maximal inhibitory concentration: 0.0032 nM
The estimate for compound 3 lay 470-fold (2.67 log units) above the measured number, outside the stated range (below it).
By their numbers in this assay, from the lowest: compound 3; then compounds 1 and 2 (each within the scatter of the next).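

In this assay, 1-hydroxybutyl in place of hydrogen on a saturated chain carbon bound to an aromatic nitrogen gives a 410-fold lower number from compound 2 to compound 3 (2.61 log units; beyond the scatter) when benzyl is kept on the amide-type nitrogen. Benzyl in place of isopropyl on that nitrogen gives a 310-fold lower number from compound 1 to compound 3 (2.49 log units; beyond the scatter) when 2-hydroxypentyl is kept, so each large step depends on the group held constant and the two groups act together here. No supporting measurement explains this gain.

The compounds shown leave open whether the hydroxyl itself matters, as a plain pentyl chain or an amine in its place would show. They also leave open whether a shorter hydroxyalkyl chain would serve as well.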